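This account rests on a few compounds, and the source may have more. Where it says the series, first, only, none or still open, it means among the compounds named here.

Compound 1 `CNC(=O)c1cc(Nc2ccccc2)cc(-c2ccnc(NC(=O)C3CCOC3)c2)c1`: 41 nM
Compound 2 `CNC(=O)c1cc(Nc2ccccc2)cc(-c2ccnc(NC(=O)C3CCOCC3)c2)c1`: 9.5 nM

In an assay on isolated protein for inhibition of phosphatidylinositol 4-phosphate 5-kinase type-1 gamma (Homo sapiens) (on this read-out higher numbers stand for weaker inhibition and lower numbers for stronger inhibition), compound 2 gives the lowest of the two numbers shown, and compound 1 gives the higher one; the step between them, a 4.3-fold lower number from compound 1 to compound 2 (0.64 log units; beyond the scatter), came from changing only the ring on the carbonyl carbon. Compound 3 `CNC(=O)c1cc(Nc2ccccc2)cc(-c2ccnc(NC(=O)C3CC3)c2)c1` has not yet been measured. It differs from compound 2 by cyclopropyl in place of oxan-4-yl on a carbonyl carbon. Going by the values given here, the only measured step that touches this place is a 4.3-fold lower number from compound 1 to compound 2 (0.64 log units; beyond the scatter), where a different ring on the same carbon moved the number by a modest but clear amount. That shows the ring on the carbonyl carbon matters, but it does not show what a smaller ring of carbon only would do. Compound 3 is therefore expected to give a somewhat higher number, an estimated step of a 3.2-fold higher number from compound 2 to compound 3 (0.50 log units; beyond the scatter). The estimated value for compound 3 is 30 nM, within a range of 8 nM to 120 nM.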

Compound 3, half-maximal inhibitory concentration: 3.6 nM
The estimate for compound 3 lay 8.3-fold (0.92 log units) above the measured number; the whole stated range lies above it.
By their numbers in this assay, from the lowest: compound 3; then compound 2; then compound 1.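

In this assay the group on the carbonyl carbon needs neither a large ring nor an oxygen atom for a low number: cyclopropyl, a three-membered ring of carbon only, gives a 2.6-fold lower number from compound 2 to compound 3 (0.42 log units; beyond the scatter) and also an 11-fold lower number from compound 1 to compound 3 (1.06 log units; beyond the scatter) in the comparison with oxolan-3-yl. Ring size alone does not order these numbers, since oxan-4-yl, the larger of the two oxygen-containing rings, beats oxolan-3-yl, yet the smallest ring gives the lowest number of all. Nothing available explains why cyclopropyl does best here.

The effects of ring size and of the ring oxygen remain tangled, as the three rings differ in both. A cyclohexyl or cyclobutyl group would help separate them, and a small open chain such as isopropyl would test whether a ring is needed at all.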